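This account rests on a few compounds, and the source may have more. Where it says the series, first, only, none or still open, it means among the compounds named here.

For the measured compounds named here, compound 2 `CC(C)=CCCN(C)C1CCN(CCCc2c[nH]c3ccc(-n4cnnc4)cc23)CC1` gives 24 nM in an assay on CHO cells for displacement of a labelled ligand from 5-hydroxytryptamine receptor 1B (Homo sapiens) (a higher number here means a weaker inhibitor, a lower number a stronger inhibitor), the lower of the two numbers measured so far; compound 1 `c1ccc(CNCC2CCN(CCCc3c[nH]c4ccc(-n5cnnc5)cc34)CC2)cc1` gives 28 nM in this assay, and a 1.2-fold lower number from compound 1 to compound 2 (0.07 log units; within the scatter) is within the scatter. Compound 3 `CN(Cc1cccs1)C1CCN(CCCc2c[nH]c3ccc(-n4cnnc4)cc23)CC1` differs from compound 2 by thiophen-2-yl in place of 3-methylbut-2-en-1-yl on a saturated chain carbon bound to an amine nitrogen. Going by the values given here, only one measured step bears on this, and it showed that a large change in the amine substituent of this core left the number unchanged. Compound 3 is therefore expected to give about 25 nM, between 10 nM and 65 nM. The step this estimate implies, a 1.0-fold higher number from compound 2 to compound 3 (0.02 log units; within the scatter), is expected to stay within the scatter.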

Compound 3, half-maximal inhibitory concentration: 140 nM
Compound 3: middle estimate off by 5.6-fold (0.75 log units), on the low side; measured number above the stated range.
By their numbers in this assay, from the lowest: compounds 2 and 1 (each within the scatter of the next); then compound 3.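

For the compounds shown here, the side group on the amine is less free than the first pair of compounds suggested: with the same count of heavy atoms, the change gives a 5.8-fold higher number from compound 2 to compound 3 (0.77 log units; beyond the scatter). A ring in this group does not by itself go with the higher number, since the other ring-bearing comparison, with methyl((thiophen-2-yl)methyl)amino replacing (benzylamino)methyl, gives a 5.0-fold higher number from compound 1 to compound 3 (0.70 log units; beyond the scatter) and compound 1 sits low. No measurement here accounts for this shift. Still open, on these data alone, is whether the thiophene itself matters, or its pairing with the methyl on the amine nitrogen. A benzyl group on that same methylated nitrogen would separate the two.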